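From Ethoxy to Isopropoxy on a Shared Core

The source may hold more compounds than are shown below. What is called first, only, known or untested is meant among the compounds shown, and "the series" means these compounds.

Compound 1 `Cc1ccc(O)c(C(=O)/C=C/c2csc3ccccc23)c1` gives 4900 nM
Compound 2 `COc1ccc(O)c(C(=O)/C=C/c2csc3ccccc23)c1` gives 640 nM
Compound 3 `CCOc1ccc(O)c(C(=O)/C=C/c2csc3ccccc23)c1` gives 5800 nM

These values come from a functional assay on KB cells (Homo sapiens) for antiproliferative activity, read by sulforhodamine B assay, with a stated time of 72 h (on this read-out lower numbers stand for stronger inhibition and higher numbers for weaker inhibition), and place compound 3 at the weak end of this small set, in a tie. The data show a 1.2-fold higher number from compound 1 to compound 3 (0.07 log units; within the scatter) and, against the methoxy analogue, a 9.1-fold higher number from compound 2 to compound 3 (0.96 log units; beyond the scatter).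

Compound 4 `CC(C)Oc1ccc(O)c(C(=O)/C=C/c2csc3ccccc23)c1` takes the next step along the chain, ethoxy to isopropoxy, with methyl in place of hydrogen on a saturated chain carbon bound to an oxygen on an aromatic ring and a saturated chain carbon. This is methyl in place of hydrogen on a saturated chain carbon bound to an oxygen on an aromatic ring and a saturated chain carbon.

Among the measured compounds shown here, the closest precedent is the methoxy to ethoxy change, which also adds a methyl and gave a modest loss, a 9.1-fold higher number from compound 2 to compound 3 (0.96 log units; beyond the scatter). That single case started from the low value of compound 2 (640 nM), whereas the ethoxy compound already sits level with the methyl compound. A repeat of the full step is therefore not expected. In this assay a small further rise, probably within the scatter, is the expectation, and the estimated step is a 1.2-fold higher number from compound 3 to compound 4 (0.08 log units; within the scatter). Compound 4 is estimated at 7000 nM, with an expected range of 2500 nM to 20000 nM.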

Compound 4, half-maximal inhibitory concentration: 10000 nM
The estimate for compound 4 lay 1.4-fold (0.15 log units) below the measured number, and the stated range covers the measured number.
By their numbers in this assay, from the lowest: compound 2; then compounds 1, 3 and 4 (each within the scatter of the next, the first and the last beyond it).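

In this assay the second added methyl behaves differently from the first: the ethoxy to isopropoxy change gives a 1.7-fold higher number from compound 3 to compound 4 (0.24 log units; within the scatter) and stays inside the scatter, whereas the methoxy to ethoxy change gave a 9.1-fold higher number from compound 2 to compound 3 (0.96 log units; beyond the scatter) and lay beyond it. Isopropoxy does separate from the methyl group, though only modestly, showing a 2.0-fold higher number from compound 1 to compound 4 (0.31 log units; beyond the scatter) where ethoxy, with a 1.2-fold higher number from compound 1 to compound 3 (0.07 log units; within the scatter) as its step, had not. Methoxy now stands more clearly alone among the four groups on the shared core, since a 16-fold higher number from compound 2 to compound 4 (1.19 log units; beyond the scatter) is the widest gap in the set and the only large one.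

On these data alone, whether the numbers stay high with a longer chain such as propoxy or butoxy, and whether hydroxy, cyclopropoxy or an amine in place of the isopropoxy could return to the level of compound 2 at 640 nM remains open. Nothing given here offers an explanation for why methoxy alone gives the low number.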